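Bombesin receptor subtype-3 agonists: ring versus open chain

A few compounds are considered here, and "the series" means these few. Any claim that something is new, unique, unknown or untested is made for them only; others in the source may bear on it.

Measured so far:
compound 1 `CCCCc1cnc(C(C)Cc2ccc(-c3ccccc3C(=O)O)cc2)[nH]1` — 184 nM
compound 2 `O=C(O)c1ccccc1-c1ccc(CCc2ncc(CC3CCCC3)[nH]2)cc1` — 7.9 nM

In an in vitro functional assay on cells for agonist activity at Bombesin receptor subtype-3 (Mus musculus), read by luminescence and calcium flux (a lower number here means that less compound is needed, a higher number that more compound is needed for the effect), compound 2 has the lowest number of the two; compound 1 stands far above it, beyond the scatter. Compound 3 `CC(C)CCc1cnc(CCc2ccc(-c3ccccc3C(=O)O)cc2)[nH]1` differs from compound 2 by isobutyl in place of cyclopentyl on a saturated chain carbon bound to an aromatic carbon. Among the compounds with values here, no measured pair isolates this change, so the size of the step is uncertain. A modest rise in the number is expected, beyond the scatter but well short of the gap to compound 1. The expected step is a 2.8-fold higher number from compound 2 to compound 3 (0.44 log units; beyond the scatter). Compound 3 is thus estimated at 22 nM, with a range from 7 nM to 70 nM.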

Compound 3, half-maximal effective concentration: 10 nM
For compound 3 the middle estimate is 2.2-fold (0.34 log units) above the measured one; low and high end bracket the measured number.
By their numbers in this assay, from the lowest: compounds 2 and 3 (each within the scatter of the next); then compound 1.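

In this assay, isobutyl in place of cyclopentyl on a saturated chain carbon bound to an aromatic carbon gives a 1.3-fold higher number from compound 2 to compound 3 (0.10 log units; within the scatter), so the cyclopentylmethyl and isopentyl forms of this side chain cannot be told apart. For this pair, the ring is not required for a number in this range. No supporting data bear on this result.

Still open, from the compounds shown here alone, is how this position responds to other groups, such as a longer chain or a terminal amine. Compound 1 differs from compound 2 and compound 3 in more than one place, so its gap cannot be assigned to a single change.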